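Chlorophenyl shift from compound 3 to compound 4

A few compounds are considered here, and "the series" means these few. Any claim that something is new, unique, unknown or untested is made for them only; others in the source may bear on it.

In a functional assay on K562 cells (Homo sapiens) for cytotoxicity, read by ELISA, with a stated time of 4 days (on this read-out lower numbers stand for stronger inhibition and higher numbers for weaker inhibition), compound 1 `Cc1cccc(-c2cc(-c3ccoc3)cc(-c3ccc(Cl)s3)n2)c1` gives 13700 nM, compound 2 `Cc1ccc(-c2cc(-c3ccoc3)cc(-c3ccc(Cl)s3)n2)cc1` gives 17900 nM and compound 3 `Clc1cccc(-c2cc(-c3ccoc3)cc(-c3ccc(Cl)s3)n2)c1` gives 22100 nM. These three values lie within the scatter of one another, so compound 3 stands level with the other two and no ranking can be drawn.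

The unmeasured compound 4 `Clc1ccc(-c2cc(-c3ccoc3)cc(-c3ccc(Cl)s3)n2)cc1` has 4-chlorophenyl in place of 3-chlorophenyl on an aromatic carbon. Among the measured compounds shown here, the closest precedent is the same change of position with a methyl group, 4-methylphenyl in place of 3-methylphenyl, which gave a 1.3-fold higher number from compound 1 to compound 2 (0.12 log units; within the scatter). Exchanging the substituent itself also moved little, with chloro in place of methyl giving a 1.6-fold higher number from compound 1 to compound 3 (0.21 log units; within the scatter). The remaining pair gave a 1.2-fold higher number from compound 2 to compound 3 (0.09 log units; within the scatter). On this evidence, no step beyond the scatter is expected in this assay, and the expected step is a 1.0-fold lower number from compound 3 to compound 4 (0.00 log units; within the scatter). For compound 4 the estimated value is 22000 nM, within an expected range of 11000 nM to 44000 nM.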

Compound 4, half-maximal inhibitory concentration: 19600 nM
The estimate for compound 4 lay 1.1-fold (0.05 log units) above the measured number; the range from low to high includes it.
By their numbers in this assay, from the lowest: compounds 1, 2, 4 and 3 (each within the scatter of the next).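

In this assay, among the compounds shown here, moving the chlorine from 3-chlorophenyl to 4-chlorophenyl gives a 1.1-fold lower number from compound 3 to compound 4 (0.05 log units; within the scatter), so this change of position, earlier seen only with methyl, now also stays within the scatter with chloro. Chloro in place of methyl on the 4-substituted phenyl gives a 1.1-fold higher number from compound 2 to compound 4 (0.04 log units; within the scatter), and changing group and position together gives a 1.4-fold higher number from compound 1 to compound 4 (0.16 log units; within the scatter), so all four compounds stand level and this aryl position shows no preference among these groups. The exchange of methyl for chloro also reads alike at both positions: the same change on two cores in this assay, a 1.6-fold higher number (0.21 log units; within the scatter) from compound 1 to compound 3 and a 1.1-fold higher number (0.04 log units; within the scatter) from compound 2 to compound 4, 1.5-fold (0.17 log units) apart, within the scatter of two such steps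

The compounds shown carry only methyl or chloro on this phenyl, so it remains open whether an amine, a carboxylic acid or a methoxy group there would move the number beyond the scatter. Also open, from the compounds shown here alone, is what replacing the furan-3-yl or 5-chlorothiophen-2-yl group would do.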